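Swapping a Pyrimidine for a Thiophene in a Porcupine Inhibitor

A few compounds are considered here, and "the series" means these few. Any claim that something is new, unique, unknown or untested is made for them only; others in the source may bear on it.

Of the compounds shown here, two have been tested in an assay on L cells for inhibition of Protein-serine O-palmitoleoyltransferase porcupine (Mus musculus), read by reporter gene assay, with a stated time of 24 h; on this read-out lower numbers stand for an effect already at smaller amounts and higher numbers for an effect only at larger amounts of compound. Compound 1 `COc1ccc2nc(NC(=O)CNC(=O)c3nn(-c4ccccc4OC)c(=O)c4ccccc34)sc2c1` gives 90 nM. Compound 2 `O=C(CSc1nc2c(c(=O)n1-c1ccccc1)SCC2)Nc1ccc(-c2cncnc2)cn1` gives 5.5 nM, the lower of the two numbers; the gap to compound 1 lies beyond the scatter of repeated measurements. Compound 3 `O=C(CSc1nc2c(c(=O)n1-c1ccccc1)SCC2)Nc1ccc(-c2ccsc2)cn1` has not been measured; it differs from compound 2 by thiophen-3-yl in place of pyrimidin-5-yl on an aromatic carbon. For the measured compounds named here, with no measured step of this kind to lean on, a modest loss is expected, a 2.7-fold higher number from compound 2 to compound 3 (0.44 log units; beyond the scatter), somewhat beyond the scatter. Compound 3 is therefore estimated at 15 nM, with a range from 4 nM to 60 nM.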

Compound 3, half-maximal effective concentration: 2 nM
Compound 3: the middle estimate sits 7.5-fold (0.88 log units) above what was measured; the whole stated range lies above it.
By their numbers in this assay, from the lowest: compound 3; then compound 2; then compound 1.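

This position, on an aromatic carbon two atoms from the ring nitrogen, accepts a change of ring size: in this assay, thiophen-3-yl in place of pyrimidin-5-yl gives a 2.8-fold lower number from compound 2 to compound 3 (0.44 log units; beyond the scatter) and so keeps the number low. For this pair, the two nitrogens of pyrimidin-5-yl are therefore not needed for a low number. Nothing available explains the size of this step. Still open, from the compounds shown here alone, is how a plain phenyl, thiophen-2-yl, or a group carrying an amine or a carboxylic acid would fare at this position.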